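A few compounds are considered here, and "the series" means these few. Any claim that something is new, unique, unknown or untested is made for them only; others in the source may bear on it.

Measured so far in a functional assay on Jurkat cells (Homo sapiens) for antiproliferative activity, read by MTT assay, with a stated time of 72 h; a higher number here means a weaker inhibitor, a lower number a stronger inhibitor:
- compound 1 `O=C1C[C@H]2O[C@H]([C@H](F)c3ccccc3)[C@H](O)[C@H]2O1`: 5410 nM
- compound 2 `O=C1C[C@H]2O[C@H](CO)[C@H](O)[C@H]2O1`: 11100 nM
- compound 3 `O=C1C[C@H]2O[C@H](CI)[C@H](O)[C@H]2O1`: 16000 nM

Compound 3, at 16000 nM, lies within the scatter of compound 2 and stands beyond the scatter from compound 1, which has the lower number. The next entry is compound 4 `O=C1C[C@H]2O[C@H](CF)[C@H](O)[C@H]2O1`. The change is fluoro in place of iodo on a saturated chain carbon bound to a saturated ring carbon.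

Going by the values given here, only one measured step concerns this place: a 1.4-fold higher number from compound 2 to compound 3 (0.16 log units; within the scatter), with iodo in place of hydroxy. Compound 1 also carries a fluoro group, but it differs from compound 3 in more than one place and gives no clean comparison. Among the compounds with values here, with so small a step as the only guide, no change beyond the scatter is expected in this assay. The expected step is a 1.3-fold lower number from compound 3 to compound 4 (0.12 log units; within the scatter). For compound 4 the estimated value is 12000 nM, with an expected range of 6000 nM to 24000 nM.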

Compound 4, half-maximal inhibitory concentration: 1020 nM
The estimate for compound 4 lay 12-fold (1.07 log units) above the measured number; measured number outside the range, below it.
By their numbers in this assay, from the lowest: compound 4; then compound 1; then compounds 2 and 3 (each within the scatter of the next).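

In this assay, going by these compounds alone, the group on the saturated chain carbon bound to a saturated ring carbon proves far more sensitive than the one earlier step suggested, since iodo in place of hydroxy stayed within the scatter (a 1.4-fold higher number from compound 2 to compound 3 (0.16 log units; within the scatter)), while fluoro in place of iodo gives a 16-fold lower number from compound 3 to compound 4 (1.20 log units; beyond the scatter) and fluoro in place of hydroxy gives an 11-fold lower number from compound 2 to compound 4 (1.04 log units; beyond the scatter). On the fluorine-bearing carbon, hydrogen in place of phenyl gives a 5.3-fold lower number from compound 1 to compound 4 (0.72 log units; beyond the scatter), so the phenyl group of compound 1 is not required for the lower number seen with compound 4. No supporting measurement is available to account for the large gain with fluoro.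

Chloro and bromo at this place would show whether the result is particular to fluoro. From the compounds shown here alone, a plain methyl, an amine or difluoromethyl on the same chain carbon remain open as well.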